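Removing the methoxy group from compound 3

The compounds below may be only part of what the source reports. "The series", "measured", "known", "first", "only" and "open" are said of these compounds alone.

In an ADME assay on HepG2 cells (Homo sapiens) for cytotoxicity, read by luminescence, CellTiter-Glo and ATP content, with a stated time of 72 h (a lower number here means that less compound is needed, a higher number that more compound is needed for the effect), compound 1 (`Fc1ccc(-c2ccc3c(NCCCNCc4ccco4)ccnc3c2)cc1`) gives 7760 nM and compound 2 (`COc1cccc(Oc2ccc3c(NCCCNCc4ccco4)ccnc3c2)c1`) gives 15500 nM, while compound 3 (`COc1ccc(-c2ccc3c(NCCCNCc4ccco4)ccnc3c2)cc1`) gives 6000 nM on the same core. Compound 3 thus stands level with compound 1 and under compound 2.

Compound 4 (`c1ccc(-c2ccc3c(NCCCNCc4ccco4)ccnc3c2)cc1`) differs from compound 3 by hydrogen in place of methoxy on an aromatic carbon, para to a large group (hydrogen in place of methoxy on an aromatic carbon). The closest measured change is methoxy in place of fluoro on an aromatic carbon (a 1.3-fold lower number from compound 1 to compound 3 (0.11 log units; within the scatter)), which stayed within the scatter. The exchange of the whole group (a 2.6-fold lower number from compound 2 to compound 3 (0.41 log units; beyond the scatter)) went beyond the scatter, but it replaced far more than the loss of one methoxy.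

In this assay no step beyond the scatter is therefore expected, with only a slight lean towards a higher number. The expected step is small (a 1.2-fold higher number from compound 3 to compound 4 (0.07 log units; within the scatter)). Compound 4 is expected at 7000 nM (estimated range 3500 nM to 14000 nM).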

Compound 4, half-maximal effective concentration: 5920 nM
The estimate for compound 4 lay 1.2-fold (0.07 log units) above the measured number; the measured number falls inside the stated range.
By their numbers in this assay, from the lowest: compounds 4, 3, 1 and 2 (each within the scatter of the next, the first and the last beyond it).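

In this assay, removing the methoxy group gives no measurable shift (a 1.0-fold lower number from compound 3 to compound 4 (0.01 log units; within the scatter)), and the replacement of fluoro by hydrogen likewise stays within the scatter (a 1.3-fold lower number from compound 1 to compound 4 (0.12 log units; within the scatter)), so hydrogen, methoxy and fluoro on this aromatic carbon cannot be told apart. Going by these compounds alone, the one step here from compound 4 that goes beyond the scatter is the exchange of the whole group (a 2.6-fold lower number from compound 2 to compound 4 (0.42 log units; beyond the scatter)), which replaces far more than a single substituent, so a change at this one carbon does not account for the gap. No measurement offers a reason for these readings.

Going by these compounds, whether this carbon would stay as undiscriminating with an amine or a carboxylic acid in place of hydrogen remains open. The compounds also leave open how a longer chain in place of the methoxy group would read.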